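From 3-bromophenyl to 2-bromophenyl, starting at a limit

The source may report more compounds than this note shows. Statements on the series, on what has been measured and on what is new or still open speak of the compounds shown alone.

Of the compounds shown here, three sharing one core have been tested in a functional assay on HUVEC cells (Homo sapiens) for antiproliferative activity, read by MTT assay, with a stated time of 24 h; on this read-out lower numbers stand for stronger inhibition and higher numbers for weaker inhibition. Among the measured compounds shown here, compound 1 `COc1cc(OC)c(-c2coc3cc(OCc4ccccc4C)ccc3c2=O)cc1OC` gives 4830 nM, the only actual number among them. Compound 2 `COc1cc(OC)c(-c2coc3cc(OCc4ccc([N+](=O)[O-])cc4)ccc3c2=O)cc1OC` stands at a limit of the assay, > 10000 nM. Compound 3 `COc1cc(OC)c(-c2coc3cc(OCc4cccc(Br)c4)ccc3c2=O)cc1OC` also stands at a limit, > 10000 nM. It therefore sits at the limit of > 10000 nM in this assay, at which 2 of the 3 values shown sit, and its true value is not known.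

Compound 4 `COc1cc(OC)c(-c2coc3cc(OCc4ccccc4Br)ccc3c2=O)cc1OC` has 2-bromophenyl in place of 3-bromophenyl, on a saturated chain carbon bound to an oxygen on an aromatic ring: 2-bromophenyl in place of 3-bromophenyl on a saturated chain carbon bound to an oxygen on an aromatic ring.

For the measured compounds named here, two measured steps bear on this change. Replacing the 2-methylphenyl group gave an at least 2.0-fold higher number from compound 1 to compound 3 (0.31 log units; beyond the scatter) with 3-bromophenyl, and an at least 2.0-fold higher number from compound 1 to compound 2 (0.31 log units; beyond the scatter) with 4-nitrophenyl. Only compound 1, with its 2-methylphenyl group, gives a number, 4830 nM, and the 2-bromophenyl group is numbered the same way. That is a single example, so the expectation is loose, and another limit remains possible.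

The expected change is an at least 1.6-fold lower number from compound 3 to compound 4 (0.22 log units; that floor lies within the scatter), toward stronger inhibition in this assay. For compound 4 the estimate is 6000 nM, with an expected range of 2000 nM to 18000 nM.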

Compound 4, half-maximal inhibitory concentration: > 10000 nM
Compound 4: only a limit was reported; the forecaster's own chance of this, stated with the estimate: 35%; middle value at least 1.6-fold (0.22 log units) from the limit.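

In this assay, the change from 3-bromophenyl to 2-bromophenyl brings no number back, and compound 4 also stands at a limit, > 10000 nM. Bromo in place of methyl on an aromatic carbon gives an at least 2.0-fold higher number from compound 1 to compound 4 (0.31 log units; beyond the scatter), so among the compounds shown, the measurable value of compound 1 goes with the 2-methylphenyl group and not with the shared numbering of the ring alone. The steps from compound 2 and from compound 3 to compound 4 cannot be read, since both ends of each step are limits: the limit of > 10000 nM in this assay, at which 3 of the 4 values shown sit.

From the compounds shown here alone, whether the 2-bromophenyl and 3-bromophenyl compounds truly differ therefore remains unknown. Also open, going by these compounds, is whether a 2-chlorophenyl or 2-ethylphenyl group on the same carbon would give a number, which would show how narrowly that value depends on the methyl group.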